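Lengthening the side chain of a glucagon receptor inhibitor

The source may hold more compounds than are shown below. What is called first, only, known or untested is meant among the compounds shown, and "the series" means these compounds.

Compound 1 `CCC[C@H](c1ccc(C(=O)NCc2nn[nH]n2)cc1)N1C(=O)C(c2cc(Cl)cc(Cl)c2)=N[C@]12CC[C@@H](C(C)(C)C)CC2` was tested in an assay on CHO cells for displacement of a labelled ligand from Glucagon receptor (Homo sapiens), read by scintillation counting, with a stated time of 60 min (a lower number here means a stronger inhibitor, a higher number a weaker inhibitor), where compound 1 gives 55 nM. One other compound is known: compound 2 `CC(C)(C)CC[C@H](c1ccc(C(=O)NCc2nn[nH]n2)cc1)N1C(=O)C(c2cncc(Cl)c2)=N[C@]12CC[C@@H](C(C)(C)C)CC2`, which in this assay gives 38 nM, a number that lies within the usual scatter of the value for compound 1, so the two cannot be told apart. Compound 3 `CC(C)CC[C@H](c1ccc(C(=O)NCc2nn[nH]n2)cc1)N1C(=O)C(c2cc(Cl)cc(Cl)c2)=N[C@]12CC[C@@H](C(C)(C)C)CC2` differs from compound 1 by isopropyl in place of methyl on a saturated chain carbon, three bonds along the chain from an amide-type nitrogen in a ring and an aromatic carbon. Among the measured compounds shown here, with no measured pair showing this change, the step from compound 1 to compound 3 is expected to stay within the scatter, a 1.2-fold lower number from compound 1 to compound 3 (0.09 log units; within the scatter). Compound 3 is therefore estimated at 45 nM, with a range from 20 nM to 110 nM.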

Compound 3, half-maximal inhibitory concentration: 22 nM
Compound 3: the middle estimate sits 2.0-fold (0.31 log units) above what was measured; measured number inside the range.
By their numbers in this assay, from the lowest: compounds 3, 2 and 1 (each within the scatter of the next, the first and the last beyond it).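

In this assay the change from methyl to isopropyl gives a 2.5-fold lower number from compound 1 to compound 3 (0.40 log units; beyond the scatter) and so shows, in a pair differing in one place, that this end of the chain affects the reading. Extending propyl to isopentyl here lowers the number instead of raising it. No measurement offered here accounts for this gain.

A single pair cannot separate the added length from the branching. As far as these compounds go, how a longer chain, or a chain ending in an amine or a carboxylic acid, would read at this place remains open.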